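Shrinking a side group to an open chain: solubility estimate

This account rests on a few compounds, and the source may have more. Where it says the series, first, only, none or still open, it means among the compounds named here.

Measured compounds:
compound 1 `c1ccc(-c2ccc3c(NCCCNCc4ccco4)ccnc3c2)cc1`, 32000 nM
compound 2 `Fc1ccc(Cc2ccc3c(NCCCNCc4ccco4)ccnc3c2)cc1`, 4200 nM
compound 3 `c1coc(CNCCCNc2ccnc3cc(CC4CCCCC4)ccc23)c1`, 4200 nM

Going by the values given here, in a physicochemical assay for solubility, with a stated time of 18 h, at pH 7.4 (a lower number here means a less soluble compound, a higher number a more soluble compound), compound 3 gives 4200 nM, which puts it level with compound 2 and together with it at the low end of the three numbers; the step of a 7.6-fold lower number from compound 1 to compound 3 (0.88 log units; beyond the scatter) is the one that sets compound 3 apart. Compound 4 `CCC(CC)c1ccc2c(NCCCNCc3ccco3)ccnc2c1` differs from compound 3 in one place: pentan-3-yl in place of cyclohexylmethyl on an aromatic carbon.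

Among the compounds with values here, two measured steps bear on this spot. The step of a 7.6-fold lower number from compound 1 to compound 2 (0.88 log units; beyond the scatter) and the step of a 7.6-fold lower number from compound 1 to compound 3 (0.88 log units; beyond the scatter) show that replacing phenyl with a larger group that carries a saturated carbon lowers the number, while no change at the digits printed from compound 2 to compound 3 (within the scatter) shows no difference between a ring that is aromatic and one that is not. Within the data shown here, no measured compound carries an open chain at this position, so the direction is uncertain. A return toward the value of compound 1 is expected, but only part way, giving an expected step of a 1.9-fold higher number from compound 3 to compound 4 (0.28 log units; within the scatter). Compound 4 is therefore estimated at 8000 nM, within a range from 3000 nM to 25000 nM.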

Compound 4, solubility: 4200 nM
For compound 4 the middle estimate is 1.9-fold (0.28 log units) above the measured one; the measured number falls inside the stated range.
By their numbers in this assay, from the lowest: compounds 2, 3 and 4 (each within the scatter of the next); then compound 1.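

In this assay, the open-chain pentan-3-yl group gives the same reading as the two ring-bearing groups, with no change at the digits printed from compound 3 to compound 4 (within the scatter) and no change at the digits printed from compound 2 to compound 4 (within the scatter), so among these compounds neither a ring nor the larger cyclohexylmethyl group is needed to stay at this level. Compound 1 alone stands apart, with a 7.6-fold lower number from compound 1 to compound 4 (0.88 log units; beyond the scatter), and among these four compounds the higher number goes only with the phenyl group, the one group joined to the core through an aromatic ring carbon rather than a saturated carbon. Nothing available explains why these three different groups give the same reading.

Going by these compounds, it remains open whether a much smaller group such as methyl would stay at the same level as compounds 2, 3 and 4 or move toward compound 1. Also open, on these data alone, is how a group carrying an amine or a hydroxyl would read at this position.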